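Methoxy in Place of Fluoro on a Leukotriene Receptor Ligand

The source may hold more compounds than are shown below. What is called first, only, known or untested is meant among the compounds shown, and "the series" means these compounds.

Of the compounds shown here, three have been measured in an assay on cell membranes from spleen (Cavia porcellus) for binding affinity to leukotriene B4 receptor 1 (Homo sapiens); a higher number here means a weaker inhibitor, a lower number a stronger inhibitor. Compound 1 `O=C(O)CCCOc1cc(-c2ccccc2)cc(-c2ccccc2)n1` gives 300 nM, and compound 2 `O=C(O)CCCCCOc1cc(-c2ccccc2Cl)cc(-c2ccccc2)n1` gives 200 nM. Compound 3 `O=C(O)CCCCCOc1cc(-c2ccccc2)cc(-c2ccc(F)cc2)n1` gives 30 nM, the lowest of the three numbers; its gap to compound 2 and its gap to compound 1 both lie beyond the usual scatter. Compound 4 `COc1ccc(-c2cc(-c3ccccc3)cc(OCCCCCC(=O)O)n2)cc1` has not yet been measured. It differs from compound 3 in one place: methoxy in place of fluoro on an aromatic carbon. Among the measured compounds shown here, no measured pair shows this exchange, so its effect in this assay is unknown. The step of a 2.0-fold higher number from compound 3 to compound 4 (0.30 log units; within the scatter) is expected to be a modest weakening, possibly no more than the scatter. Compound 4 is therefore estimated at 60 nM, within a range from 20 nM to 200 nM.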

Compound 4, half-maximal inhibitory concentration: 1000 nM
Compound 4: the middle estimate sits 17-fold (1.22 log units) below what was measured; measured number outside the range, above it.
By their numbers in this assay, from the lowest: compound 3; then compounds 2 and 1 (each within the scatter of the next); then compound 4.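

In this assay, among the compounds shown here, the exchange of 4-fluorophenyl for 4-methoxyphenyl gives a 33-fold higher number from compound 3 to compound 4 (1.52 log units; beyond the scatter), the first step that isolates a single change. It shows that this place, para to a large group, is sensitive to the group it carries, and that one added heavy atom can accompany a large loss. No measurement at hand accounts for the size of this step. As far as these compounds go, whether a hydrogen, a methyl or a hydroxyl here would stay near fluoro or fall towards methoxy remains open.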